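A few compounds are considered here, and "the series" means these few. Any claim that something is new, unique, unknown or untested is made for them only; others in the source may bear on it.

For the measured compounds named here, compound 2 `COc1cc(-c2nn(-c3cccc(NC(=O)c4ccc(Cl)c(C(F)(F)F)c4)c3)cc2-c2ccncc2)ccc1Cl` is one of three compounds measured in a functional assay on SK-MEL-5 cells (Homo sapiens) for inhibition, read by sulforhodamine B assay, with a stated time of 48 h; on this read-out lower numbers stand for stronger inhibition of growth and higher numbers for weaker inhibition of growth. In this assay compound 2 gives 1380 nM, the highest of the three numbers. Compound 1 `O=C(Nc1cccc(-n2cc(-c3ccncc3)c(-c3ccc(Cl)c(O)c3)n2)c1)Nc1ccc(Cl)c(Cl)c1` gives 570 nM in this assay, and compound 3 `O=C(Nc1cccc(-n2cc(-c3ccncc3)c(-c3ccc(Cl)c(O)c3)n2)c1)Nc1cc(C(F)(F)F)cc(C(F)(F)F)c1` gives 600 nM; both lie beyond the scatter below compound 2. Compound 4 `COc1cc(-c2nn(-c3cccc(NC(=O)Nc4cccc(C(F)(F)F)c4)c3)cc2-c2ccncc2)ccc1Cl` has not yet been measured in this assay. It differs from compound 2 in one place: (3-(trifluoromethyl)phenyl)amino in place of 4-chloro-3-(trifluoromethyl)phenyl on a carbonyl carbon. Going by the values given here, no step between measured compounds differing in a single place is available, so the size of this change cannot be read off directly. Still, compound 1 gives 570 nM and compound 3 gives 600 nM, and both carry an arylamino group on a carbonyl carbon as compound 4 does, so the account expects a modest downward step from compound 2 to compound 4 that may or may not exceed the scatter. It expects compound 4 to give around 750 nM in this assay, with a range from 300 nM to 1900 nM. That expectation corresponds to a step of a 1.8-fold lower number from compound 2 to compound 4 (0.26 log units; within the scatter).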

Compound 4, concentration for 50% growth inhibition: 720 nM
The estimate for compound 4 lay 1.0-fold (0.02 log units) above the measured number; measured number inside the range.
By their numbers in this assay, from the lowest: compounds 1, 3, 4 and 2 (each within the scatter of the next, the first and the last beyond it).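

For the compounds shown here, the first step in this assay between compounds differing in one place is a 1.9-fold lower number from compound 2 to compound 4 (0.28 log units; within the scatter), so on this carbonyl carbon (3-(trifluoromethyl)phenyl)amino can stand in place of 4-chloro-3-(trifluoromethyl)phenyl without a step beyond the scatter. The exchange removes a chlorine and brings in a nitrogen with one hydrogen-bond donor, while the heavy-atom count and the single aromatic ring stay the same. Nothing available here bears on why the step has this size.

On these data alone, the separate contributions of the chlorine and the amino nitrogen remain open, as the two change together in this step. Also open, as far as these compounds go, is how a methylene linker or a piperazine on the same carbonyl carbon would read in this assay.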